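Cyano in place of chloro: compound 3 to compound 4

The source may hold more compounds than are shown below. What is called first, only, known or untested is meant among the compounds shown, and "the series" means these compounds.

Values measured in a functional assay on HepG2 cells (Homo sapiens) for cytotoxicity, read by MTT assay, with a stated time of 24 h (on this read-out higher numbers stand for weaker inhibition and lower numbers for stronger inhibition), so far:
- compound 1 `N#Cc1ccc(S(=O)(=O)N2C/C(=C\c3cccnc3)C(=O)/C(=C/c3ccccc3F)C2)cc1` gives 6600 nM
- compound 2 `Cc1ccc(S(=O)(=O)N2C/C(=C\c3ccncc3)C(=O)/C(=C/c3ccccc3F)C2)cc1` gives 9700 nM
- compound 3 `O=C1/C(=C/c2ccncc2)CN(S(=O)(=O)c2ccc(Cl)cc2)C/C1=C\c1ccccc1F` gives 5300 nM

Compound 3 at 5300 nM stands within the scatter of both compound 1 and compound 2, so these three values do not separate. The next change leads to compound 4 `N#Cc1ccc(S(=O)(=O)N2C/C(=C\c3ccncc3)C(=O)/C(=C/c3ccccc3F)C2)cc1` with cyano in place of chloro on an aromatic carbon as the difference. Among the compounds with values here, the only measured step at this place is a 1.8-fold lower number from compound 2 to compound 3 (0.26 log units; within the scatter) and it offers no size beyond the scatter. Compound 1 carries the same 4-cyanophenyl group but differs elsewhere, and it gives 6600 nM in the same range. No step beyond the scatter is therefore expected in this assay and the estimated change is a 1.1-fold higher number from compound 3 to compound 4 (0.05 log units; within the scatter) without a firm direction. Compound 4 is expected at 6000 nM with a range of 3000 nM to 12000 nM as estimated here.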

Compound 4, half-maximal inhibitory concentration: 4500 nM
Beside the measured number, compound 4's estimate is 1.3-fold (0.12 log units) above it; the range from low to high includes it.
By their numbers in this assay, from the lowest: compounds 4, 3, 1 and 2 (each within the scatter of the next, the first and the last beyond it).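

In this assay, cyano and chloro do not separate at this position (a 1.2-fold lower number from compound 3 to compound 4 (0.07 log units; within the scatter)). Cyano in place of methyl gives the only step at this position beyond the scatter, and a modest one (a 2.2-fold lower number from compound 2 to compound 4 (0.33 log units; beyond the scatter)). Pyridin-4-yl in place of pyridin-3-yl stays within the scatter (a 1.5-fold lower number from compound 1 to compound 4 (0.17 log units; within the scatter)), so that change does not separate the two compounds either.

No evidence at hand bears on why the steps fall this way. From the compounds shown here alone, whether an amine or a carboxylic acid at this position would give a larger step remains open.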